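A few compounds are considered here, and "the series" means these few. Any claim that something is new, unique, unknown or untested is made for them only; others in the source may bear on it.

Measured to date in a functional assay on U-251 cells (Homo sapiens) for inhibition, read by sulforhodamine B assay, with a stated time of 48 h; a lower number here means a stronger inhibitor of growth, a higher number a weaker inhibitor of growth:
compound 1 `COc1ccc(-c2[nH]c3ccc(OC)cc3c2/C=C(\C#N)S(=O)(=O)c2ccccc2)cc1`, 563 nM;
compound 2 `CC(=O)/C(=C\c1c(-c2ccccc2)[nH]c2ccccc12)S(=O)(=O)c1ccccc1`, 1200 nM;
compound 3 `COc1ccc(-c2[nH]c3ccccc3c2/C=C(\C#N)S(=O)(=O)c2ccccc2)cc1`, 473 nM.

Compound 3 has the lowest number of the three; compound 1 sits within the scatter of it, while compound 2 lies beyond the scatter with a higher number. The next step is to compound 4 `N#C/C(=C\c1c(-c2ccccc2)[nH]c2ccccc12)S(=O)(=O)c1ccccc1`: hydrogen in place of methoxy on an aromatic carbon, here on a six-membered aromatic ring of carbon only, para to a large group. Within the data shown here, the one measured step of this kind, a 1.2-fold lower number from compound 1 to compound 3 (0.08 log units; within the scatter), was within the scatter, though it concerned a methoxy on another part of the shared core. Among the measured compounds shown here, compound 2 also lacks this methoxy but carries an acetyl where compound 3 carries a nitrile, and no single step covers that pair; its number is simply the higher of the two. In this assay the step for compound 4 is therefore expected to be small, a 1.2-fold higher number from compound 3 to compound 4 (0.07 log units; within the scatter), with no confident direction. Compound 4 is estimated at 550 nM, within 250 nM to 1200 nM.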

Compound 4, concentration for 50% growth inhibition: 2600 nM
For compound 4 the middle estimate is 4.7-fold (0.67 log units) below the measured one; measured number above the stated range.
By their numbers in this assay, from the lowest: compounds 3 and 1 (each within the scatter of the next); then compound 2; then compound 4.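

In this assay the change from 4-methoxyphenyl to phenyl gives a 5.5-fold higher number from compound 3 to compound 4 (0.74 log units; beyond the scatter) at this place, whereas the methoxy replaced on another part of the shared core gave a 1.2-fold lower number from compound 1 to compound 3 (0.08 log units; within the scatter) and stayed within the scatter. The size of this replacement therefore does not carry from one place on the core to the other. With phenyl at this place, cyano in place of acetyl gives a 2.2-fold higher number from compound 2 to compound 4 (0.34 log units; beyond the scatter) and leaves the nitrile with the higher number of that pair.

On these data alone, whether ethoxy, hydroxy or fluorine at this place would keep the number of compound 3 stays open, as does the effect of acetyl alongside 4-methoxyphenyl. No available evidence bears on either step.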